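Chloro in place of methyl on the amide aryl ring

The source may hold more compounds than are shown below. What is called first, only, known or untested is meant among the compounds shown, and "the series" means these compounds.

Compound 1 `O=C(Nc1ccc(Cl)c(-c2nnc3c(Cl)cccn23)c1)c1ccc(Cl)cc1` gives 73600 nM in a functional assay on A549 cells (Homo sapiens) for antiproliferative activity, read by MTT assay, with a stated time of 72 h; on this read-out higher numbers stand for weaker inhibition and lower numbers for stronger inhibition. Compound 2 `Cc1cc(Cl)ccc1C(=O)Nc1ccc(Cl)c(-c2nnc3c(Cl)cccn23)c1` reaches only a limit of this assay, > 100000 nM.

Compound 2 therefore stands at the upper edge of what the measurement reports, namely (the limit of > 100000 nM in this assay, at which 1 of the 2 values shown sits), so its true value is not known as a number. Within the data shown here, the single measured step, an at least 1.3-fold higher number from compound 1 to compound 2 (0.13 log units; that floor lies within the scatter), sits within the scatter and shows no clear change. Compound 3 `O=C(Nc1ccc(Cl)c(-c2nnc3c(Cl)cccn23)c1)c1ccc(Cl)cc1Cl` differs from compound 2 by chloro in place of methyl on an aromatic carbon; in other words, a chloro group stands where the methyl stood, ortho to a large group and meta to a chloro group. The step from compound 1 to compound 2 is the only one that touches this place, and it was small. The expected step is an at least 1.1-fold lower number from compound 2 to compound 3 (0.04 log units; that floor lies within the scatter), that is, no change beyond the scatter. Compound 3 is therefore expected to give about 90000 nM, within a range of 30000 nM to 300000 nM, and it may again reach only a limit.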

Compound 3, half-maximal inhibitory concentration: 61300 nM
The estimate for compound 3 lay 1.5-fold (0.17 log units) above the measured number; measured number inside the range.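

With chloro in place of hydrogen at this position, ortho to a large group, the result is a 1.2-fold lower number from compound 1 to compound 3 (0.08 log units; within the scatter), so a measured number now shows that a chloro group here causes no change that can be told from the scatter. Among these compounds, with chloro in place of methyl at the same position, the result is an at least 1.6-fold lower number from compound 2 to compound 3 (0.21 log units; that floor lies within the scatter), which gives the first reading of this exchange, though the floor alone shows no clear change and the true step may be larger. Compound 2 reaches only a limit, so this step is known only as a floor: the limit of > 100000 nM in this assay, at which 1 of the 3 values shown sits.

As far as these compounds go, only hydrogen, methyl and chloro appear at this position, so it remains open whether any group there can move the number clearly beyond the scatter. An amine or a carboxylic acid at this place would test that question.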